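Methoxy in Place of Formyl on the Sulfonyl Aryl Ring

The compounds below may be only part of what the source reports. "The series", "measured", "known", "first", "only" and "open" are said of these compounds alone.

The read-out throughout is an ADME assay on BJ cells (Homo sapiens) for antiproliferative activity, with a stated time of 72 h; a lower number here means that less compound is needed, a higher number that more compound is needed for the effect.

Compound 1 `COC(=O)c1cc(=O)c2c(OC)cc(OC)cc2n1C` reaches only the limit > 37900 nM.
Compound 2 `COc1ccc(-c2cc(=O)c3c(OC)cc(OC)cc3n2S(=O)(=O)c2ccc(C=O)cc2)cc1` reaches only the limit > 34400 nM.
Compound 3 `COc1ccc(-c2cc(=O)c3c(OC)cc(OC)cc3n2S(=O)(=O)c2c(C(C)C)cc(C(C)C)cc2C(C)C)cc1` reaches only the limit > 341000 nM.

Compound 2 stands at a limit, and it stands there with the other two, since both further values shown are limits as well, as marked by the limit of > 341000 nM in this assay, at which 1 of the 3 values shown sits, and (the limit of > 37900 nM in this assay, at which 1 of the 3 values shown sits). Its own limit is marked by the limit of > 34400 nM in this assay, at which 1 of the 3 values shown sits. Among the compounds with values here, no step between measured compounds can be counted from this set, so there is no measured size of change to lean on.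

Compound 4 `COc1ccc(-c2cc(=O)c3c(OC)cc(OC)cc3n2S(=O)(=O)c2ccc(OC)cc2)cc1` differs from compound 2 in one place: methoxy in place of formyl on an aromatic carbon. The formyl leaves and a methoxy enters, para to a large group on the phenyl of the sulfonyl.

With every measured value sitting at a limit, no step beyond the scatter is expected in this assay in either direction. Compound 4 is expected to give 40000 nM, with a range from 10000 nM to 150000 nM. The expected step that the limit leaves unreadable from compound 2 to compound 4 is estimated to be none beyond the scatter, and the assay is expected most likely to report a limit again.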

Compound 4, half-maximal effective concentration: > 82700 nM
Compound 4: only a limit was reported; the forecaster's own chance of this, stated with the estimate: 80%; at least 2.0-fold (0.31 log units) between middle value and limit.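

Within the data shown here, compound 2 and compound 4 are both reported only as limits in this assay, and no step between them can be read. The compounds shown leave open whether methoxy in place of formyl on an aromatic carbon changes the result in this assay at all.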